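From isopropyl to ethyl: a small trim

The source may hold more compounds than are shown below. What is called first, only, known or untested is meant among the compounds shown, and "the series" means these compounds.

In an ADME assay on microsomes from liver (Mus musculus, strain CD1) for metabolic stability, read by HPLC, using NADPH, with a stated time of 30 min, tested at 0.5 uM (a higher number here means faster removal of the compound, a lower number slower removal), compound 2 `CC(C)[C@H]1CC[C@@H](n2c(=O)[nH]c3ncc(N)cc3c2=O)CC1` gives 4.8 mL.min-1.g-1 and compound 1 `CC[C@H]1CC[C@@H](n2c(=O)[nH]c3ncc(NC(C)=O)cc3c2=O)CC1` gives 2.7 mL.min-1.g-1, two numbers within the usual scatter of each other. Compound 3 `CC[C@H]1CC[C@@H](n2c(=O)[nH]c3ncc(N)cc3c2=O)CC1` has hydrogen in place of methyl on a saturated chain carbon bound to a saturated chain carbon and a saturated ring carbon, which turns isopropyl into ethyl. Among the measured compounds shown here, no measured pair shows this change alone. The expected step in this assay is therefore small, a slight move toward slower removal that stays within the scatter: a 1.4-fold lower number from compound 2 to compound 3 (0.14 log units; within the scatter). For compound 3 the estimated value is 3.5 mL.min-1.g-1, with an expected range from 1.8 mL.min-1.g-1 to 6.8 mL.min-1.g-1.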

Compound 3, intrinsic clearance in microsomes in the Mus musculus assay: 1.7 mL.min-1.g-1
Estimate against measurement, compound 3: 2.1-fold (0.31 log units) above; measured number below the stated range.
By their numbers in the Mus musculus assay, from the lowest: compounds 3, 1 and 2 (each within the scatter of the next, the first and the last beyond it).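

In the Mus musculus assay the change from isopropyl to ethyl gives a 2.8-fold lower number from compound 2 to compound 3 (0.45 log units; beyond the scatter) and, unlike the gap between the two earlier compounds, stands clear of the scatter. With ethyl kept, hydrogen in place of acetyl on a nitrogen on an aromatic ring gives, in the Mus musculus assay, a 1.6-fold lower number from compound 1 to compound 3 (0.20 log units; within the scatter) and cannot be told from the scatter. In a physicochemical assay for solubility, read by nephelometry, measured as kinetic solubility (a lower number here means a less soluble compound, a higher number a more soluble compound), compound 2 gives 17000 nM. In the physicochemical assay compound 3 gives only a limit, < 17000 nM, and the step to it cannot be read: the limit of < 17000 nM in the physicochemical assay, at which 1 of the 2 values shown sits.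

On these data alone, whether a lone methyl or a longer chain at this position would follow the same trend in the Mus musculus assay remains open.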